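Trifluoromethyl in place of bromo: lipophilicity notes

The source may hold more compounds than are shown below. What is called first, only, known or untested is meant among the compounds shown, and "the series" means these compounds.

Compound 1 `O=C(Nc1cccc(Br)c1)c1ccc2cccc(O)c2n1` serves as the reference point of the series. In a physicochemical assay for lipophilicity, read by HPLC (a higher number here means a more lipophilic compound, a lower number a more polar compound), compound 1 gives 2.5. Compound 2 `O=C(Nc1ccc(Br)cc1)c1ccc2cccc(O)c2n1` differs from it in the core: 4-bromophenyl in place of 3-bromophenyl on an amide-type nitrogen. In this assay compound 2 gives 2.5, and the step is no change at the digits printed from compound 1 to compound 2 (within the scatter). Compound 3 `O=C(Nc1cccc(C(F)(F)F)c1)c1ccc2cccc(O)c2n1` carries the change (trifluoromethyl in place of bromo on an aromatic carbon). In this assay compound 3 gives 2.5, with the step of no change at the digits printed from compound 1 to compound 3 (within the scatter).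

Compound 4 `O=C(Nc1ccc(C(F)(F)F)cc1)c1ccc2cccc(O)c2n1` is not yet measured in this assay. It differs from compound 2 by trifluoromethyl in place of bromo on an aromatic carbon. Among the compounds with values here, this is the same kind of change as the one taking compound 1 to compound 3, though not the same: the place is meta to a large group in the first case and para to a large group in the second. The expected step is no change at the digits printed from compound 2 to compound 4 (within the scatter), placed beside the earlier one. This expectation rests on the step of no change at the digits printed from compound 1 to compound 3 (within the scatter) and on the step of no change at the digits printed from compound 1 to compound 2 (within the scatter), both within the scatter. In this assay compound 4 is estimated at 2.5, expected to lie between 2.2 and 2.8.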

Compound 4, partition coefficient: 2.5
Compound 4: middle estimate and measured number agree at the digits printed, within the range that was stated.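

In this assay trifluoromethyl in place of bromo gives no change at the digits printed from compound 2 to compound 4 (within the scatter) and, in the other pair, no change at the digits printed from compound 1 to compound 3 (within the scatter) so the change carries across these two pairs with both steps within the scatter. Within the data shown here, this shows only that the swap left the printed reading undisturbed in the two cases at hand, one of them para to a large group, and it does not show that the two groups are interchangeable on other cores or in any other read-out. Nothing available here bears on why the steps read as they do.

The compounds shown leave open whether the same swap stays within the scatter when the shared core carries an amine or a carboxylic acid in place of the hydroxyl. They also leave open how the swap reads when a longer chain stands on the amide nitrogen in place of the substituted phenyl ring.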